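Aryltriazole amide series: methoxy in place of ethyl

The source may hold more compounds than are shown below. What is called first, only, known or untested is meant among the compounds shown, and "the series" means these compounds.

Compound 1 `CC(C)n1ncc2c(C(=O)NCc3cn(-c4cccc(F)c4)nn3)cccc21` gives 36100 nM in a functional assay on PC-3 cells (Homo sapiens) for inhibition, read by MTT assay, with a stated time of 72 h; on this read-out higher numbers stand for weaker inhibition and lower numbers for stronger inhibition.
Compound 2 `Cc1cccc(-n2cc(CNC(=O)c3cccc4c3cnn4C(C)C)nn2)c1` gives 32300 nM in this assay.
Compound 3 `CCc1ccc(-n2cc(CNC(=O)c3cccc4c3cnn4C(C)C)nn2)cc1` gives 26600 nM in this assay.

On the numbers shown compound 3 sits lowest, yet a 1.4-fold lower number from compound 1 to compound 3 (0.13 log units; within the scatter) and a 1.2-fold lower number from compound 2 to compound 3 (0.08 log units; within the scatter) are within the scatter, as is a 1.1-fold lower number from compound 1 to compound 2 (0.05 log units; within the scatter), so the three compounds cannot be told apart. Compound 4 `COc1ccc(-n2cc(CNC(=O)c3cccc4c3cnn4C(C)C)nn2)cc1` differs from compound 3 by methoxy in place of ethyl on an aromatic carbon. Among the compounds with values here, no measured step exchanges an ethyl for a methoxy; every measured exchange on the phenyl ring left the numbers within the scatter. The step of a 1.1-fold higher number from compound 3 to compound 4 (0.02 log units; within the scatter) is therefore expected to stay within the scatter as well. Compound 4 is estimated at 28000 nM in this assay, with a range of 12000 nM to 65000 nM.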

Compound 4, half-maximal inhibitory concentration: 34300 nM
Compound 4: the middle estimate sits 1.2-fold (0.09 log units) below what was measured; the measured number falls inside the stated range.
By their numbers in this assay, from the lowest: compounds 3, 2, 4 and 1 (each within the scatter of the next).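

In this assay, within the data shown here, the step of a 1.3-fold higher number from compound 3 to compound 4 (0.11 log units; within the scatter) is the first exchange of ethyl for methoxy at this place para to a large group, and it adds a hydrogen-bond acceptor by the count without a readable change. The steps of a 1.1-fold higher number from compound 2 to compound 4 (0.03 log units; within the scatter) and a 1.1-fold lower number from compound 1 to compound 4 (0.02 log units; within the scatter) also stay within the scatter, so 4-methoxyphenyl cannot be told apart from 3-methylphenyl or 3-fluorophenyl on the aromatic nitrogen. No supporting data bear on why this position shows so little response.

Going by these compounds, what an amine or a carboxylic acid in place of methoxy would do to the number stays open. Also open, on these data alone, is whether any replacement on this phenyl ring can move the number beyond the scatter.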